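Amide for Alkyl on the Ring Nitrogen

The source may report more compounds than this note shows. Statements on the series, on what has been measured and on what is new or still open speak of the compounds shown alone.

Compound 1, `Cc1cccc(C#Cc2nc3c(s2)C(=O)NCC3)c1`, reaches only the limit of an assay on HEK293 cells for negative allosteric modulation of metabotropic glutamate receptor 5 (Homo sapiens), read by FLIPR, with a stated time of 1 h (on this read-out higher numbers stand for weaker inhibition and lower numbers for stronger inhibition), giving > 10000 nM, a limit rather than a number. Compound 2, `CCCCN1CCc2nc(C#Cc3ccccc3)sc2C1`, likewise gives > 10000 nM in this assay, again a limit and not a measured figure. Both values sit at the limit of > 10000 nM in this assay, at which 2 of the 2 values shown sit, so compound 2 stands at the limit with nothing shown that separates it from compound 1. Compound 3, `O=C(C1CCCC1)N1CCc2nc(C#Cc3ccccc3)sc2C1`, differs from compound 2 in one place: cyclopentylcarbonyl in place of butyl on an amine nitrogen in a ring. No step between measured compounds is shown, so the size of this change can only be guessed; a shift beyond the usual scatter cannot be excluded, yet a limit coming back is the likeliest outcome. The step from compound 2 to compound 3 is expected to be an at least 1.2-fold lower number from compound 2 to compound 3 (0.09 log units; that floor lies within the scatter). Compound 3 is therefore estimated at 8000 nM, between 1500 nM and 30000 nM.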

Compound 3, half-maximal inhibitory concentration: > 10000 nM
Compound 3: a limit, no number (the forecaster's own chance of this, stated with the estimate: 60%); middle value at least 1.2-fold (0.09 log units) from the limit.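

In this assay compound 3 gives > 10000 nM, a limit and not a number, so no step can be read between compound 2 and compound 3: the limit of > 10000 nM in this assay, at which 3 of the 3 values shown sit.

The compounds shown leave open whether cyclopentylcarbonyl in place of butyl changes inhibition at all.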